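Removing One Chlorine from a Benzyl Ether

The source may report more compounds than this note shows. Statements on the series, on what has been measured and on what is new or still open speak of the compounds shown alone.

Three measured compounds share one core and differ only in the benzyl ether at one end. Compound 1 `Cc1ccc(NC(=S)NC(=O)c2ccc(OCc3ccccc3)cc2)cc1-c1nc2ccccc2[nH]1` carries a plain benzyl group, and in a functional assay on SW-620 cells (Homo sapiens) for inhibition, read by MTT assay, with a stated time of 48 h (a higher number here means a weaker inhibitor, a lower number a stronger inhibitor), compound 1 gives 67100 nM. Compound 2 `Cc1ccc(NC(=S)NC(=O)c2ccc(OCc3ccccc3F)cc2)cc1-c1nc2ccccc2[nH]1` adds a single fluorine to that ring, and in this assay compound 2 gives 6440 nM; the step of a 10-fold lower number from compound 1 to compound 2 (1.02 log units; beyond the scatter) is a large gain. Compound 3 `Cc1ccc(NC(=S)NC(=O)c2ccc(OCc3cccc(Cl)c3Cl)cc2)cc1-c1nc2ccccc2[nH]1` carries two chlorines instead. In this assay compound 3 gives > 100000 nM, which is a limit of the measurement and not a number (the limit of > 100000 nM in this assay, at which 1 of the 3 values shown sits). The steps of an at least 1.4-fold higher number from compound 1 to compound 3 (0.17 log units; that floor lies within the scatter) and an at least 15-fold higher number from compound 2 to compound 3 (1.19 log units; beyond the scatter) describe how compound 3 compares with the other two.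

Compound 4 `Cc1ccc(NC(=S)NC(=O)c2ccc(OCc3ccccc3Cl)cc2)cc1-c1nc2ccccc2[nH]1` is made from compound 3 by the change (hydrogen in place of chloro on an aromatic carbon), leaving a 2-chlorobenzyl group, the chlorine counterpart of the 2-fluorobenzyl group of compound 2. That fluorine gave the large step of a 10-fold lower number from compound 1 to compound 2 (1.02 log units; beyond the scatter), while the two chlorines of compound 3 gave the large loss an at least 15-fold higher number from compound 2 to compound 3 (1.19 log units; beyond the scatter), so the single chlorine is expected to land between those outcomes. The expected step of an at least 3.3-fold lower number from compound 3 to compound 4 (0.52 log units; beyond the scatter) is an estimated gain of uncertain size. Compound 4 is expected to give about 30000 nM in this assay, within a range from 5000 nM to 150000 nM.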

Compound 4, half-maximal inhibitory concentration: 57100 nM
Beside the measured number, compound 4's estimate is 1.9-fold (0.28 log units) below it; the measured number falls inside the stated range.
By their numbers in this assay, from the lowest: compound 2; then compounds 4 and 1 (each within the scatter of the next). At a limit, above all of these: compound 3.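

Chloro in place of fluoro gives an 8.9-fold higher number from compound 2 to compound 4 (0.95 log units; beyond the scatter), so the gain at this position belongs to fluorine and does not extend to the other halogen shown. Chloro in place of hydrogen gives a 1.2-fold lower number from compound 1 to compound 4 (0.07 log units; within the scatter), which means that in this assay the single chlorine cannot be told apart from the plain benzyl group of compound 1. The step of an at least 1.7-fold lower number from compound 3 to compound 4 (0.24 log units; that floor lies within the scatter) starts from a limit held by compound 3, so it gives only a floor and cannot show what the second chlorine costs: the limit of > 100000 nM in this assay, at which 1 of the 4 values shown sits.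

The compounds shown leave open whether the lower number is unique to fluorine or would also come with a methyl, methoxy or nitrile group on that same carbon. They also leave open whether fluorine placed elsewhere on the benzyl ring would give a similar number.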